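A few compounds are considered here, and "the series" means these few. Any claim that something is new, unique, unknown or untested is made for them only; others in the source may bear on it.

Compound 1, `COc1ccc(Cc2cc(-c3cccs3)nn(CC(=O)Nc3ccc(Br)cc3)c2=O)cc1`, is one of three compounds already tested in a functional assay on HL-60 cells (Homo sapiens), read by calcium flux; a lower number here means that less compound is needed, a higher number that more compound is needed for the effect. In this assay compound 1 gives > 50000 nM, which is a limit of the assay and not a measured number. Compound 2, `COc1cccc(Cc2cc(-c3cccs3)nn(CC(=O)Nc3ccc(F)cc3)c2=O)c1`, gives > 50000 nM, again only a limit. Compound 3, `COc1ccc(-c2cc(Cc3cccc(OC)c3)c(=O)n(CC(=O)Nc3ccc(F)cc3)n2)cc1`, gives > 50000 nM, a limit as well. Because (the limit of > 50000 nM in this assay, at which 3 of the 3 values shown sit), compound 1 cannot be placed in any order against the other two; it simply shares the limit with them. Within the data shown here, the single measured step, a step that the two limits leave unreadable from compound 2 to compound 3, exchanges thiophen-2-yl for 4-methoxyphenyl on an aromatic carbon, but its size stays hidden behind the two limits.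

Compound 4, `COc1ccc(Cc2cc(Cc3ccccc3)nn(CC(=O)Nc3ccc(Br)cc3)c2=O)cc1`, is the compound still to be measured. It differs from compound 1 by benzyl in place of thiophen-2-yl on an aromatic carbon. The measured step from compound 2 to compound 3 is the only one that also replaces the thiophen-2-yl group, and it gives no readable size, so nothing measured tells how large the shift to benzyl should be, nor its direction. The expectation therefore rests on the shared limit. Compound 4 is estimated at 70000 nM, within a range from 20000 nM to 300000 nM, most probably reported once more only as a limit. This corresponds to an expected step that the limit leaves unreadable from compound 1 to compound 4, none beyond the scatter.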

Compound 4, half-maximal effective concentration: > 50000 nM
Compound 4: only a limit was reported; the forecaster's own chance of this, stated with the estimate: 85%; the middle value lies beyond the limit too.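

In this assay compound 4 gives > 50000 nM, which is a limit and not a measured number. No size can be read for the change from compound 1 to compound 4, because both stop at the same limit: the limit of > 50000 nM in this assay, at which 4 of the 4 values shown sit. With no measured number among the compounds shown, how any of their structural changes affects the concentration needed stays open.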